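The source may report more compounds than this note shows. Statements on the series, on what has been measured and on what is new or still open speak of the compounds shown alone.

Measured in a functional assay on MCF7 cells (Homo sapiens) for cytotoxicity, read by sulforhodamine B assay, with a stated time of 48 h (a higher number here means a weaker inhibitor, a lower number a stronger inhibitor), so far:

Compound 1 `C=CCOc1ccc(F)cc1C(=O)c1cccnc1` gives > 100000 nM as a limit.
Compound 2 `C=CCOc1cc(Br)ccc1C(=O)c1cccnc1` gives > 100000 nM as a limit.
Compound 3 `C=CCOc1ccccc1C(=O)c1cccnc1` gives > 100000 nM as a limit.

Compound 2 has no number of its own, only a limit, and it shares that position with the other two compounds: the limit of > 100000 nM in this assay, at which 3 of the 3 values shown sit, is all the set offers. No order among the three can be read.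

The change to compound 4 `O=C(c1cccnc1)c1ccc(Br)cc1O` reads hydrogen in place of allyl on an oxygen on an aromatic ring and amounts to hydrogen in place of allyl on an oxygen on an aromatic ring. Two measured steps exist in the series, a step that the two limits leave unreadable from compound 1 to compound 3 and a step that the two limits leave unreadable from compound 2 to compound 3 and neither gives a size. Both take away a halogen and leave the allyl group untouched, so they bear on the new step only weakly. Going by the values given here, no measured compound lacks the allyl group.

With nothing pointing either way in this assay the working expectation starts from compound 2 and its limit of > 100000 nM as the only anchor. The expected step is a number no higher from compound 2 to compound 4 (the limit leaves the size open) in size, with no shift beyond the scatter anticipated and a limit again quite likely.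

For compound 4 the estimated value is 100000 nM with an expected range from 40000 nM to 250000 nM in this read-out.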

Compound 4, half-maximal inhibitory concentration: > 100000 nM
Compound 4 ended at the assay's limit (the forecaster's own chance of this, stated with the estimate: 65%); the middle value lies on the limit itself.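

In this assay, going by these compounds alone, compound 4 gives > 100000 nM, which is a limit, and compound 2 also stands only as a limit, so no step between compound 2 and compound 4 can be read. The compounds shown leave open which change to the shared core, if any, would give a measurable value rather than this shared position: the limit of > 100000 nM in this assay, at which 4 of the 4 values shown sit.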